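Chloro in place of methoxy on compound 3

The compounds below may be only part of what the source reports. "The series", "measured", "known", "first", "only" and "open" are said of these compounds alone.

Measured in a functional assay on SMMC-7721 cells (Homo sapiens) for cytotoxicity, read by MTT assay, with a stated time of 48 h; a lower number here means a stronger inhibitor, a higher number a weaker inhibitor:
Compound 1 `COc1cc(-c2noc(N)c2-c2ccc(Cl)cc2)cc(OC)c1OC`: > 50000 nM, a limit
Compound 2 `COc1cc(-c2noc(NC(C)=O)c2-c2ccc(Cl)cc2)cc(OC)c1OC`: > 50000 nM, a limit
Compound 3 `COc1ccc(-c2c(-c3cc(OC)c(OC)c(OC)c3)noc2N(C(C)=O)C(C)=O)cc1`: 1360 nM

Within the data shown here, compound 3 gives 1360 nM, the only true number among the three. The other two compounds stand at the limit of > 50000 nM in this assay, at which 2 of the 3 values shown sit.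

Compound 4 `COc1cc(-c2noc(N(C(C)=O)C(C)=O)c2-c2ccc(Cl)cc2)cc(OC)c1OC` keeps the substitution on nitrogen of compound 3 and changes one group: chloro in place of methoxy on an aromatic carbon. This is chloro in place of methoxy on an aromatic carbon, para to a large group, or 4-methoxyphenyl to 4-chlorophenyl.

Among the measured compounds shown here, no measured step covers this change. For the measured compounds named here, the only step available is a step that the two limits leave unreadable from compound 1 to compound 2, and it concerns acetyl in place of hydrogen on a nitrogen, so it offers no size to carry over. The sole hint is indirect: compound 1 and compound 2 both carry the 4-chlorophenyl and both stand at the limit of > 50000 nM in this assay, at which 2 of the 3 values shown sit. They differ from compound 4 on the nitrogen, so this hint is weak. A moderate loss in this assay is therefore expected, with wide uncertainty. The expected change is a 2.9-fold higher number from compound 3 to compound 4 (0.47 log units; beyond the scatter), towards a weaker value. For compound 4 the estimate is 4000 nM, with an expected range from 800 nM to 30000 nM.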

Compound 4, half-maximal inhibitory concentration: > 50000 nM
Compound 4 gave a limit, no number (the forecaster's own chance of this, stated with the estimate: 15%); middle value at least 12-fold (1.09 log units) away from the limit.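

In this assay, among these compounds, chloro in place of methoxy on an aromatic carbon, para to a large group, with the diacetylamino group kept, gives an at least 36-fold higher number from compound 3 to compound 4 (1.56 log units; beyond the scatter), the first readable step and a large one, showing that activity at this position depends strongly on which group is present. Compound 4 gives > 50000 nM, which is a limit and not a number. The steps among compound 1, compound 2 and compound 4 cannot be read, so changes on the nitrogen show no measurable difference while the 4-chlorophenyl is present, and all three compounds carrying that ring stand at the same limit, with only compound 3, the one compound carrying 4-methoxyphenyl, giving a number: the limit of > 50000 nM in this assay, at which 3 of the 4 values shown sit.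

The compounds shown leave open whether methoxy is specifically needed at this position or whether a hydroxy, a methyl, a fluoro or an ethoxy would also give a measurable value. They also leave open whether the 4-methoxyphenyl would give a number with a free amino or a single acetylamino group on the nitrogen, rather than the diacetylamino group of compound 3.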